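The compounds below may be only part of what the source reports. "The series", "measured", "known", "first", "only" and "open" are said of these compounds alone.

Measured compounds:
compound 1, `ClCc1ccc(Cn2cnc3c(Cl)ncnc32)cc1`: 11800 nM
compound 2, `Nc1nc(Cl)c2ncn(Cc3ccc(CCl)cc3)c2n1`: 19500 nM
compound 3, `ClCc1ccccc1Cn1cnc2c(Cl)ncnc21`: 34700 nM

The three measured compounds were tested in a functional assay on DU-145 cells (Homo sapiens) for cytotoxicity, read by sulforhodamine B assay, with a stated time of 48 h; a higher number here means a weaker inhibitor of growth, a lower number a stronger inhibitor of growth. Compound 1 gives 11800 nM in this assay, and compound 2 gives 19500 nM. The two differ by one change, (amino in place of hydrogen on an aromatic carbon), and the step that this change made is a 1.7-fold higher number from compound 1 to compound 2 (0.22 log units; within the scatter). Compound 3 has the same atoms as compound 1 joined differently; the difference between the two cores is not broken down here. In this assay compound 3 gives 34700 nM, a number that lies beyond the scatter from compound 1 but within the scatter of compound 2, so compound 3 and compound 2 cannot be ordered against each other on these data.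

Compound 4, `Nc1nc(Cl)c2ncn(Cc3ccccc3CCl)c2n1`, has not yet been measured. It stands to compound 3 as compound 2 stands to compound 1: the change is amino in place of hydrogen on an aromatic carbon, and the place described for it is the same, word for word, as for the change from compound 1 to compound 2, so this is the same change made on the other core. Within the data shown here, with only one earlier instance to go on, the expectation is that it repeats: the step from compound 3 to compound 4 is estimated at a 1.7-fold higher number from compound 3 to compound 4 (0.22 log units; within the scatter), resting on the earlier step of a 1.7-fold higher number from compound 1 to compound 2 (0.22 log units; within the scatter). Compound 4 is therefore expected to give about 58000 nM in this assay, with a range from 30000 nM to 115000 nM.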

Compound 4, concentration for total growth inhibition: 32400 nM
For compound 4 the middle estimate is 1.8-fold (0.25 log units) above the measured one; the measured number falls inside the stated range.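

In this assay, the amino change carried to the other core gives a 1.1-fold lower number from compound 3 to compound 4 (0.03 log units; within the scatter), so this step, like the earlier one, stays inside the scatter. Set side by side, the two steps do not differ by more than repeated measurements of this kind would allow: the same change on two cores in this assay, a 1.7-fold higher number (0.22 log units; within the scatter) from compound 1 to compound 2 and a 1.1-fold lower number (0.03 log units; within the scatter) from compound 3 to compound 4, 1.8-fold (0.25 log units) apart, within the scatter of two such steps. Among these compounds, this shows that, in these two pairs, amino in place of hydrogen on an aromatic carbon produces no step that can be told from the scatter on either core, and that the two cores cannot be separated by their response to it; it does not show that the change carries a fixed size or direction from one core to the other, as both steps are small and only two pairs are available.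

The compounds shown leave open whether a hydroxyl or a methoxy group in place of that hydrogen would give a step beyond the scatter. They also leave open whether the amino change would stay as small on a core with a longer chain in place of the chloromethyl group.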